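A few compounds are considered here, and "the series" means these few. Any claim that something is new, unique, unknown or untested is made for them only; others in the source may bear on it.

Measured compounds in a functional assay for antagonist activity at C-X-C chemokine receptor type 3 (Homo sapiens); a higher number here means a weaker inhibitor, a lower number a stronger inhibitor:

compound 1, `CNC(=O)c1cnc(N2CCN(C3CCN(Cc4ccc(Cl)cc4F)CC3)[C@@H](C)C2)c(Cl)c1`, 18 nM
compound 2, `CNC(=O)c1cnc(N2CCN(C3CCN(Cc4ccc(Cl)cc4Cl)CC3)[C@@H](C)C2)c(Cl)c1`, 17 nM

Compound 2 carries the smaller of the two numbers, but the gap between them (a 1.1-fold lower number from compound 1 to compound 2 (0.02 log units; within the scatter)) is within the scatter, so the two compounds are not distinguished by this assay.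

Compound 3, `CNC(=O)c1cnc(N2CCN(C3CCN(Cc4ccc(F)cc4Cl)CC3)[C@@H](C)C2)c(Cl)c1`, differs from compound 2 by fluoro in place of chloro on an aromatic carbon. Going by the values given here, the only measured step, a 1.1-fold lower number from compound 1 to compound 2 (0.02 log units; within the scatter), exchanges a fluoro for a chloro at another aromatic carbon of the same ring and stays within the scatter. Among the compounds with values here, no measured pair reports a halogen exchange at the carbon meta to the chloro group and para to the large group, so the bearing of that step on compound 3 is indirect. Taking it as the sole guide, the step from compound 2 to compound 3 in this assay is expected to be a 1.2-fold higher number from compound 2 to compound 3 (0.07 log units; within the scatter), i.e. no change beyond the scatter. Compound 3 is therefore estimated at 20 nM, with a range from 9 nM to 45 nM.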

Compound 3, half-maximal inhibitory concentration: 58 nM
Compound 3: the middle estimate sits 2.9-fold (0.46 log units) below what was measured, and the stated range ends below it.
By their numbers in this assay, from the lowest: compounds 2 and 1 (each within the scatter of the next); then compound 3.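

In this assay, the change from 2,4-dichlorobenzyl to 2-chloro-4-fluorobenzyl gives a 3.4-fold higher number from compound 2 to compound 3 (0.53 log units; beyond the scatter), so the aromatic carbon para to the large group responds to the halogen exchange, whereas the change from 4-chloro-2-fluorophenyl to 2,4-dichlorophenyl, a 1.1-fold lower number from compound 1 to compound 2 (0.02 log units; within the scatter), does not separate its two compounds. The exchange of the two halogens on the ring gives a 3.2-fold higher number from compound 1 to compound 3 (0.51 log units; beyond the scatter), which shows that the same pair of halogens can read differently according to where each sits, and across these three compounds the two with chloro para to the large group are within the scatter of each other, while the one with fluoro there has the higher number. Nothing available here accounts for this sensitivity to chloro over fluoro at this carbon.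

The compounds shown leave open whether a bromo, a methyl or a methoxy group at this carbon would track with the chloro or with the fluoro, and what plain hydrogen there would give. Also open, as far as these compounds go, is whether the gap between chloro and fluoro persists with a longer chain in place of the methyl on the amide nitrogen.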